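A few compounds are considered here, and "the series" means these few. Any claim that something is new, unique, unknown or untested is made for them only; others in the source may bear on it.

Measured so far:
compound 1 `CC(C)(C)OC(=O)CN1CCc2c(sc(NC(=O)Nc3ccc(Cl)cc3)c2C(N)=O)C1` — > 25000 nM
compound 2 `CCN1CCc2sc(NC(=O)Nc3ccc(Cl)cc3)c(C(N)=O)c2CC1` — 5800 nM

In a functional assay (strain AB) with Danio rerio as the target, read by microscopy, with a stated time of 1 h (on this read-out lower numbers stand for an effect already at smaller amounts and higher numbers for an effect only at larger amounts of compound), compound 1 gives only a limit, > 25000 nM, not a number. Compound 2 gives 5800 nM in this assay. Compound 3 `CC(C)(C)OC(=O)CCCCN1CCc2c(sc(NC(=O)Nc3ccc(Cl)cc3)c2C(N)=O)C1` is not yet measured; it differs from compound 1 by 3-(tert-butoxycarbonyl)propyl in place of tert-butoxycarbonyl on a saturated chain carbon bound to an amine nitrogen in a ring. Within the data shown here, no step between measured compounds is available, and with compound 1 sitting at the limit of > 25000 nM in this assay, at which 1 of the 2 values shown sits, the size of the change on extending the chain cannot be read from the data. Compound 3 is expected to stay near compound 1, with a small move in either direction, hardly beyond the scatter. The expected step is an at least 1.2-fold lower number from compound 1 to compound 3 (0.09 log units; that floor lies within the scatter). For compound 3 the estimate is 20000 nM, with a range from 5000 nM to 60000 nM.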

Compound 3, half-maximal effective concentration: 710 nM
Compound 3: middle estimate off by 28-fold (1.45 log units), on the high side; the whole stated range lies above it.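

In this assay, the saturated chain carbon bound to an amine nitrogen in a ring proves sensitive to chain length: 3-(tert-butoxycarbonyl)propyl in place of tert-butoxycarbonyl gives an at least 35-fold lower number from compound 1 to compound 3 (1.54 log units; beyond the scatter). The tert-butoxycarbonyl end is present in both compounds, so at this position it is compatible with a measurable effect once the chain is extended. Compound 1 is only a limit, so this step is a floor: the limit of > 25000 nM in this assay, at which 1 of the 3 values shown sits.

Still open, on these data alone, is whether a longer chain would lower the number further, or a shorter one would retain the effect. Also open, as far as these compounds go, is whether a carboxylic acid or an amine at the chain end could replace tert-butoxycarbonyl.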